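Cytotoxicity on macrophage cells: trimethoxyphenyl analogue

This account rests on a few compounds, and the source may have more. Where it says the series, first, only, none or still open, it means among the compounds named here.

Measured so far:
compound 1 `COc1cccc(-c2cc(-c3ccc(C4NC(=O)c5ccccc5N4)cc3)nc(N)n2)c1OC` — > 400000 nM
compound 2 `Nc1nc(-c2ccccc2)cc(-c2ccc(C3NC(=O)c4ccccc4N3)cc2)n1` — "not determined" (no result reported)

In an ADME assay on J774.A1 cells (Mus musculus) for cytotoxicity, read by MTT assay, with a stated time of 72 h (a lower number here means that less compound is tolerated, a higher number that more compound is tolerated), compound 1 gives > 400000 nM, which is a limit of the assay and not a number. For the measured compounds named here, compound 2 `Nc1nc(-c2ccccc2)cc(-c2ccc(C3NC(=O)c4ccccc4N3)cc2)n1` has no result in this assay; it therefore stands at no number within the set, and the only value shown is the limit of compound 1, at which one of the two values shown sits (the limit of > 400000 nM in this assay, at which 1 of the 2 values shown sits). Compound 3 `COc1cc(-c2cc(-c3ccc(C4NC(=O)c5ccccc5N4)cc3)nc(N)n2)cc(OC)c1OC` differs from compound 2 by 3,4,5-trimethoxyphenyl in place of phenyl on an aromatic carbon. No measured step exists for this change, so the size of the step cannot be read from the data; given the one limit shown, no movement beyond the scatter is expected, with a limit again the most likely outcome. Compound 3 is expected to give 400000 nM in this assay, in the range 100000 nM to 400000 nM.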

Compound 3, half-maximal cytotoxic concentration: 103000 nM
Estimate against measurement, compound 3: 3.9-fold (0.59 log units) above, and the stated range covers the measured number.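

For the compounds shown here, at this aromatic carbon, compound 3, with its 3,4,5-trimethoxyphenyl, gives 103000 nM in this assay, the first number here that is not a limit, so less compound is tolerated with this group in place. As far as these compounds go, replacing 2,3-dimethoxyphenyl with 3,4,5-trimethoxyphenyl gives an at least 3.8-fold lower number from compound 1 to compound 3 (0.58 log units; beyond the scatter), so the aryl substitution at this position can change cytotoxicity, although the full size of the step stays unknown. Compound 1 stands at a limit of the assay and not at a number: the limit of > 400000 nM in this assay, at which 1 of the 3 values shown sits.

The step from compound 2 to compound 3 cannot be read, which leaves the comparison with plain phenyl open. Also open, from the compounds shown here alone, is how a single methoxy group, an amine or a carboxylic acid on this aryl ring would compare.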